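Replacing a methylpiperazine with a pyrazole on a urea scaffold

This account rests on a few compounds, and the source may have more. Where it says the series, first, only, none or still open, it means among the compounds named here.

Measured compounds:
- compound 1, `Cc1cc(C)c(NC(=O)N(Cc2ccc(N3CCN(C)CC3)cc2)C2CCCCCC2)c(C)c1`: > 1 mg/kg
- compound 2, `COc1cccc(CN(Cc2cccc(-c3cc[nH]n3)c2)C(=O)Nc2c(SC)cc(C)nc2SC)c1`: > 0.1 mg/kg
- compound 3, `CSc1cc(C)nc(SC)c1NC(=O)N(Cc1ccccc1)Cc1cccc(-c2ccn(C)n2)c1`: < 1 mg/kg

In a functional assay on a cell-free system (plasma) with sterol O-acyltransferase, Soat (Rattus norvegicus) as the target (a lower number here means that less compound is needed, a higher number that more compound is needed for the effect), compound 1 gives > 1 mg/kg, which is a limit of the assay and not a number. For compound 2 the value > 0.1 mg/kg is likewise a limit. For compound 3 the value < 1 mg/kg is also a limit. Going by the values given here, no step between two measured compounds is given, so the three values only bracket the range in which these ureas act.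

Compound 4, `Cc1cc(C)c(NC(=O)N(Cc2ccc(-c3cn[nH]c3)cc2)C2CCCCCC2)c(C)c1`, has not yet been measured. It differs from compound 1 by 1H-pyrazol-4-yl in place of 4-methylpiperazin-1-yl on an aromatic carbon. Among the compounds with values here, all three measured values sit at limits, so no measured step indicates what this exchange does in this assay. Compound 3, which carries a methylated pyrazole, sits at the limit of < 1 mg/kg in this assay, at which 1 of the 3 values shown sits, while compound 1 sits at the limit of > 1 mg/kg in this assay, at which 1 of the 3 values shown sits, so the direction of the step from compound 1 to compound 4 is expected to be towards a lower dose, of a size beyond the scatter, as an at least 1.2-fold lower number from compound 1 to compound 4 (0.09 log units; that floor lies within the scatter). Compound 4 is therefore estimated at 0.8 mg/kg, expected within 0.25 mg/kg to 3 mg/kg.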

Compound 4, dose for half-maximal effect: > 1 mg/kg
Compound 4 was reported as a limit; the forecaster's own chance of this, stated with the estimate: 60%; middle value at least 1.2-fold (0.09 log units) away from the limit.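

In this assay compound 4 gives > 1 mg/kg, which is a limit of the assay and not a number. Compound 1 also stands at a limit, so the step between compound 1 and compound 4 cannot be read. The compounds shown leave open how far 1H-pyrazol-4-yl in place of 4-methylpiperazin-1-yl changes the dose needed, or whether it changes it at all.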